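Removing One Methoxy Group from Compound 2

This account rests on a few compounds, and the source may have more. Where it says the series, first, only, none or still open, it means among the compounds named here.

- compound 1 `Cc1cccc(NS(=O)(=O)c2ccc(N3CCNC3=O)cc2)c1` gives 370 nM in a functional assay (CEM-VLB cells, Homo sapiens) for antiproliferative activity, read by sulforhodamine B assay, with a stated time of 48 h; a higher number here means a weaker inhibitor, a lower number a stronger inhibitor
- compound 2 `COc1cc(NS(=O)(=O)c2ccc(N3CCNC3=O)cc2)cc(OC)c1` gives 1010 nM in this assay

Compound 2 has the higher of these two numbers, which makes it the weaker inhibitor of the pair, and its gap to compound 1 lies beyond the usual scatter of repeated measurements. The next molecule, compound 3 `COc1cccc(NS(=O)(=O)c2ccc(N3CCNC3=O)cc2)c1` has not yet been measured. It keeps the shared core and differs from compound 2 by a single swap, hydrogen in place of methoxy on an aromatic carbon while the other methoxy group stays.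

Among the compounds with values here, no measured pair shows this swap in isolation, so there is no direct guide to its size. Within the data shown here, the only anchors are compound 1 at 370 nM and compound 2 at 1010 nM and the expectation is a value within or near that span. The expected move is a 2.0-fold lower number from compound 2 to compound 3 (0.31 log units; beyond the scatter) in this assay and it is a modest one towards a lower number. In this assay the estimate for compound 3 is 500 nM with an expected range from 200 nM to 1200 nM for a single measurement.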

Compound 3, half-maximal inhibitory concentration: 700 nM
The estimate for compound 3 lay 1.4-fold (0.15 log units) below the measured number; low and high end bracket the measured number.
By their numbers in this assay, from the lowest: compounds 1, 3 and 2 (each within the scatter of the next, the first and the last beyond it).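

In this assay, taking one methoxy group off compound 2 and leaving hydrogen on that aromatic carbon gives a 1.4-fold lower number from compound 2 to compound 3 (0.16 log units; within the scatter) and so, with this swap now seen on its own, the step stays within the usual scatter of repeated measurements. The group that remains on the ring can be compared as well: methoxy in place of methyl on an aromatic carbon gives a 1.9-fold higher number from compound 1 to compound 3 (0.28 log units; within the scatter) and this step also stays within the scatter, so neither single change can be told apart from measurement noise in this set. No supporting data are available to explain either step.

From the compounds shown here alone, these three compounds cover only hydrogen, methyl and methoxy on these aromatic carbons, so it remains open whether a different kind of group, such as an amine, a carboxylic acid or a chlorine atom, would produce a step beyond the scatter. Going by these compounds, it is also open how a ring carrying only hydrogen at both of these carbons would compare with compound 3.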